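Compound 3 and a 3-chlorophenyl exchange

The compounds below may be only part of what the source reports. "The series", "measured", "known", "first", "only" and "open" are said of these compounds alone.

Measured in a functional assay on KB cells (Homo sapiens) for inhibition, read by sulforhodamine B assay; on this read-out higher numbers stand for weaker inhibition of growth and lower numbers for stronger inhibition of growth:
compound 1 `FC(F)(F)c1ccc(-c2ccc(-c3ccc(-c4nc5ccccc5[nH]4)cc3)cc2)cc1` gives 47200 nM
compound 2 `COc1cc(-c2ccc(-c3ccc(-c4nc5ccccc5[nH]4)cc3)cc2)cc(OC)c1OC` gives 2980 nM
compound 3 `Oc1cccc2[nH]c(-c3ccc(-c4ccc(-c5ccc(C(F)(F)F)cc5)cc4)cc3)nc12` gives 4320 nM

Compound 3 stands within the scatter of compound 2 and far from compound 1, as an 11-fold lower number from compound 1 to compound 3 (1.04 log units; beyond the scatter) shows. That step is a hydroxy in place of hydrogen on an aromatic carbon, and compound 4 `Oc1cccc2[nH]c(-c3ccc(-c4ccc(-c5cccc(Cl)c5)cc4)cc3)nc12` does not alter this feature. Compound 4 differs from compound 3 in one place only: 3-chlorophenyl in place of 4-(trifluoromethyl)phenyl on an aromatic carbon. This is 3-chlorophenyl in place of 4-(trifluoromethyl)phenyl on an aromatic carbon.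

Within the data shown here, no measured step covers this exchange, so an 11-fold lower number from compound 1 to compound 3 (1.04 log units; beyond the scatter) gives no direct guide to its size. The nearest evidence is an aryl difference without the hydroxy, where compound 1 reads 47200 nM and compound 2 reads 2980 nM. Those values lie far apart, so a wide range is warranted, but they do not speak for chlorine. In this assay, the expected result is a 1.2-fold lower number from compound 3 to compound 4 (0.09 log units; within the scatter), with no clear change beyond the scatter. For compound 4 the estimated value is 3500 nM, with an expected range from 1200 nM to 10000 nM.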

Compound 4, concentration for 50% growth inhibition: 2280 nM
The estimate for compound 4 lay 1.5-fold (0.19 log units) above the measured number; the measured number falls inside the stated range.
By their numbers in this assay, from the lowest: compounds 4, 2 and 3 (each within the scatter of the next); then compound 1.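

In this assay, 3-chlorophenyl in place of 4-(trifluoromethyl)phenyl gives a 1.9-fold lower number from compound 3 to compound 4 (0.28 log units; within the scatter), so with the hydroxy kept, this position on the six-membered aromatic ring accepts the exchange without a change beyond the scatter. Among these compounds, the exchange also replaces a group of 10 heavy atoms with one of 7, and this smaller group reads within the scatter of the larger one, although the single step alters the substituent and its place on the ring together and cannot separate the two. Nothing shown explains why the two aryl groups read alike.

On these data alone, it remains open whether the 3-chlorophenyl group would read the same without the hydroxy, given an 11-fold lower number from compound 1 to compound 3 (1.04 log units; beyond the scatter) with the 4-(trifluoromethyl)phenyl group. As far as these compounds go, it is also open whether an amine or a carboxylic acid on this aryl ring would stay within the scatter of these values.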